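A few compounds are considered here, and "the series" means these few. Any claim that something is new, unique, unknown or untested is made for them only; others in the source may bear on it.

In an ADME assay on BHK-21 cells (Mesocricetus auratus) for cytotoxicity, read by MTT assay (a higher number here means that more compound is tolerated, a lower number that less compound is tolerated), compound 3 (`C/C(=N\NC(N)=S)c1ccc2c(c1)nc(-c1ccc(Cl)cc1)n2C1CCCCC1`) reads > 100000 nM and this is a limit of the assay, not a number. Going by the values given here, compound 3 is the only one of the measured compounds at that limit (the limit of > 100000 nM in this assay, at which 1 of the 3 values shown sits) and so its true position is unknown. Compound 4 (`COc1ccc(-c2nc3cc(/C(C)=N/NC(N)=S)ccc3n2C2CCCCC2)c(OC)c1`) has 2,4-dimethoxyphenyl in place of 4-chlorophenyl on an aromatic carbon of the shared core.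

Two pieces of evidence bear on this change. Among the compounds with values here, the one measured step is an at least 2.6-fold higher number from compound 2 to compound 3 (0.42 log units; beyond the scatter) and it came with chloro in place of hydrogen on an aromatic carbon, so the chloro group that compound 4 lacks is tied to the high reading. Without that chloro group, compound 2 (`C/C(=N\NC(N)=S)c1ccc2c(c1)nc(-c1ccccc1)n2C1CCCCC1`) gives 38000 nM in this assay as a measured number. Compound 1 (`COc1ccc(-c2nc3cc(/C(C)=N/NC(N)=O)ccc3n2C2CCCCC2)c(OC)c1`) carries the same 2,4-dimethoxyphenyl group as compound 4, and compound 1 gives 19000 nM in this assay as a measured number.

A drop is therefore expected, meaning that less compound would be tolerated, and the expected size is an at least 3.3-fold lower number from compound 3 to compound 4 (0.52 log units; beyond the scatter) with the caveat that it starts from a limit. For compound 4 the estimate is 30000 nM with an expected range from 12000 nM to 80000 nM in this measurement.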

Compound 4, half-maximal cytotoxic concentration: 17000 nM
Compound 4: middle estimate off by 1.8-fold (0.25 log units), on the high side, within the range that was stated.
By their numbers in this assay, from the lowest: compounds 4, 1 and 2 (each within the scatter of the next, the first and the last beyond it). At a limit, above all of these: compound 3.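

In this assay, putting 2,4-dimethoxyphenyl in place of 4-chlorophenyl on this aromatic carbon gives an at least 5.8-fold lower number from compound 3 to compound 4 (0.76 log units; beyond the scatter), and the reading of compound 3 at the start of that step is a limit of the assay, not a number: the limit of > 100000 nM in this assay, at which 1 of the 4 values shown sits.

A step between two measured numbers now stands beside it, a 2.2-fold lower number from compound 2 to compound 4 (0.35 log units; beyond the scatter), so at this position the 2,4-dimethoxyphenyl group reads beyond the scatter of plain phenyl, and the loss of the chloro group is not the whole of the change. On the amine nitrogen, the group with sulfur in place of the group with oxygen gives a 1.1-fold lower number from compound 1 to compound 4 (0.05 log units; within the scatter), which lies within the scatter, so with 2,4-dimethoxyphenyl in place this exchange makes no readable difference in this assay.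

Going by these compounds, it remains open which of the two methoxy groups goes with the lower number, and whether a single methoxy, a fluoro or a methyl group on the phenyl ring would read nearer to compound 2 or to compound 3. Also open, on these data alone, is whether the exchange of sulfur and oxygen stays equally silent when the ring carries chloro or no substituent at all.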